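Shared core series: the step from compound 2 to compound 4

The source may hold more compounds than are shown below. What is called first, only, known or untested is meant among the compounds shown, and "the series" means these compounds.

Three compounds of the series have a number in a functional assay on HepG2 cells (Homo sapiens) for antiproliferative activity, read by CCK-8 assay, with a stated time of 72 h, tested at 8 uM; a lower number here means a weaker effect, a higher number a stronger effect of the compound at the concentration tested. Compound 1 `COC(CCn1cnc2c(NCc3ccc(C(=O)Nc4ccccc4N)cc3)nc(Cl)nc21)OC` gives 34.2%. Compound 2 `CC1CCN(c2nc(Cl)nc3c2ncn3Cc2ccc(/C=C/C(=O)Nc3ccccc3N)cc2)CC1` gives 32.2%. Compound 3 `Nc1ccccc1NC(=O)c1ccc(Cn2cnc3c(NCc4ccccc4)nc(Cl)nc32)cc1` gives 62.8%. Compound 2 stands lowest of the three numbers; compound 1 is its nearest neighbour and lies within the usual scatter of it, so the two are not told apart here; compound 3 lies furthest from compound 2, and that gap is beyond the scatter.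

Compound 4 `Nc1ccccc1NC(=O)/C=C/c1ccc(Cn2cnc3c(Nc4cccc(OC(F)(F)F)c4)nc(Cl)nc32)cc1` differs from compound 2 in one place: (3-(trifluoromethoxy)phenyl)amino in place of 4-methylpiperidin-1-yl on an aromatic carbon. Going by the values given here, no measured pair of the series shows this change, so its size cannot be read off a step. What the numbers do show is that compound 3, which carries an amino group with one hydrogen-bond donor on the same aromatic carbon of the core, gives 62.8%, while compound 2 with a donor-free substituent there gives 32.2%. For the step of a number 13.8 percentage points higher from compound 2 to compound 4 (beyond the scatter) a rise is therefore expected, of a size that may or may not clear the scatter, since the two compounds also differ in the linker to the benzamide. Compound 4 is estimated at 46% in this assay, within a range of 26% to 68%.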

Compound 4, a percentage reported as inhibition, at one concentration (the size of the read-out at that concentration, not a potency): 37.6%
Compound 4: middle estimate off by 8.4 percentage points, on the high side, and the stated range covers the measured number.
By their numbers in this assay, from the lowest: compounds 2, 1 and 4 (each within the scatter of the next); then compound 3.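

In this assay, placing (3-(trifluoromethoxy)phenyl)amino in place of 4-methylpiperidin-1-yl on this aromatic carbon gives a number 5.4 percentage points higher from compound 2 to compound 4 (within the scatter), so the two compounds are not told apart at the concentration tested. Going by these compounds alone, this is the first direct reading at this position: with the linker to the benzamide held constant, exchanging a non-aromatic ring without a hydrogen-bond donor for an aromatic ring on an amino group with a hydrogen-bond donor leaves no change that can be read beyond the scatter. No measurement bearing on this outcome is available, so the result stands as an observation only.

Compound 3 differs from compound 4 in more than one place, so the separate contributions of the group on this carbon and of the linker to its number cannot be read from the compounds shown. Also open, from the compounds shown here alone, is whether morpholin-4-yl or unsubstituted phenylamino on the same aromatic carbon, with this linker, would give a number that can be told apart from those of compound 2 and compound 4.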